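Methyl on a ring nitrogen in two xanthine-like series

A few compounds are considered here, and "the series" means these few. Any claim that something is new, unique, unknown or untested is made for them only; others in the source may bear on it.

Compound 1, `CCCCn1c(=O)[nH]c(=O)c2[nH]cnc21`: 21400 nM
Compound 2, `CCCCn1c(=O)n(C)c(=O)c2[nH]cnc21`: 1900 nM
Compound 3, `CCCn1cnc2c1c(=O)[nH]c(=O)n2CCC`: 18200 nM

Measured in an assay on membranes from brain for displacement of a labelled ligand from adenosine receptor A1 (Cavia porcellus) (on this read-out higher numbers stand for weaker inhibition and lower numbers for stronger inhibition), compound 1 gives 21400 nM and compound 2 gives 1900 nM. The change between them, (methyl in place of hydrogen on an aromatic nitrogen), made a step of an 11-fold lower number from compound 1 to compound 2 (1.05 log units; beyond the scatter).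

Compound 3 has `CCCn1cnc2c1c(=O)[nH]c(=O)n2CCC` and gives 18200 nM in this assay. The difference between the core of compound 1 and the core of compound 3 is not broken down here. The unmeasured compound 4, `CCCn1cnc2c1c(=O)n(C)c(=O)n2CCC`, differs from compound 3 by methyl in place of hydrogen on an aromatic nitrogen. This is the same kind of change as in the measured pair, yet not the same: the place is meta to a propyl group (3 heavy atoms) here, where it was meta to a butyl group (4 heavy atoms) before.

Since the step from compound 1 to compound 2 was an 11-fold lower number from compound 1 to compound 2 (1.05 log units; beyond the scatter), a step of similar size, a 9.6-fold lower number from compound 3 to compound 4 (0.98 log units; beyond the scatter), is expected from compound 3 to compound 4 in this assay. Compound 4 is therefore estimated at 1900 nM, likely between 700 nM and 5000 nM.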

Compound 4, inhibition constant: 9400 nM
Compound 4: middle estimate off by 4.9-fold (0.69 log units), on the low side, outside the stated range (above it).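

In this assay, the same replacement of hydrogen by methyl gave a 1.9-fold lower number from compound 3 to compound 4 (0.29 log units; within the scatter), so on this core its effect cannot be told apart from the ordinary spread of repeated measurements. Set beside the earlier step, the size of the change did not carry over from one core to the other: the same change on two cores in this assay, an 11-fold lower number (1.05 log units; beyond the scatter) from compound 1 to compound 2 and a 1.9-fold lower number (0.29 log units; within the scatter) from compound 3 to compound 4, 5.8-fold (0.76 log units) apart, beyond the scatter of two such steps. Going by these compounds alone, these two pairs show only that the step is not a fixed amount for this change; they do not show which difference between the two cores matters, and they give no rule for any further core.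

Going by these compounds, it remains open whether a longer group on that ring nitrogen, such as ethyl or propyl in place of methyl, would give a large step or a small one on either core. Also open, on these data alone, is how the same methyl would behave on a core carrying an amine or a carboxylic acid.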